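Trimming the urea tail: stability of compound 4

The compounds below may be only part of what the source reports. "The series", "measured", "known", "first", "only" and "open" are said of these compounds alone.

Compound 3 `CC(C)(C)NC(=O)NCCS(=O)(=O)NC(=O)c1ccc(Nc2nc(NC3(c4ccc(Cl)cc4)CC3)nc(OCC(F)(F)F)n2)cc1` shares its core with compound 1 `O=C(NS(=O)(=O)c1ccc(F)cc1)c1ccc(Nc2nc(NC3(c4ccc(Cl)cc4)CC3)nc(OCC(F)(F)F)n2)cc1` and compound 2 `CC(C)S(=O)(=O)NC(=O)c1ccc(Nc2nc(NC3(c4ccc(Cl)cc4)CC3)nc(OCC(F)(F)F)n2)cc1` and differs from them only in the group on the sulfonyl sulfur. In an ADME assay on microsomes from liver (Rattus norvegicus) for metabolic stability, with a stated time of 10 min (on this read-out higher numbers stand for a more stable compound and lower numbers for a less stable compound), compound 1 gives 99%, compound 2 gives 96% and compound 3 gives 93%. On these numbers compound 3 sits at the low end, but the steps of a number 6 percentage points lower from compound 1 to compound 3 (within the scatter) and a number 3 percentage points lower from compound 2 to compound 3 (within the scatter), like a number 3 percentage points lower from compound 1 to compound 2 (within the scatter), all lie within the scatter, so the three compounds cannot be told apart in this assay.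

Compound 4 `CC(C)C(=O)NCCS(=O)(=O)NC(=O)c1ccc(Nc2nc(NC3(c4ccc(Cl)cc4)CC3)nc(OCC(F)(F)F)n2)cc1` is reached from compound 3 by the change (isopropyl in place of (tert-butyl)amino on a carbonyl carbon). Among the compounds with values here, none of the measured steps touches this carbonyl carbon; all three vary the group on the sulfonyl sulfur, and none of them moves beyond the scatter in this assay. Within the data shown here, there is therefore no measured step that bears directly on the change from compound 3 to compound 4, and the only guide is that every variation made so far has left this assay essentially unchanged.

Compound 4 is accordingly expected to show a number 1 percentage points lower from compound 3 to compound 4 (within the scatter), a step no larger than the scatter. The estimate for compound 4 in this assay is 92%, in the range 82% to 100%.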

Compound 4, percent of the compound remaining: 84%
Compound 4: the middle estimate sits 8 percentage points above what was measured; measured number inside the range.
By their numbers in this assay, from the lowest: compounds 4, 3, 2 and 1 (each within the scatter of the next, the first and the last beyond it).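

In this assay, replacing (tert-butyl)amino with isopropyl on the carbonyl carbon gives a number 9 percentage points lower from compound 3 to compound 4 (within the scatter), so this change, the only one here made away from the sulfonyl sulfur, cannot on its own be told from the scatter. Read as whole groups on the sulfonyl sulfur, however, the 2-((isopropylcarbonyl)amino)ethyl group is the only one so far that separates from others, with a number 12 percentage points lower from compound 2 to compound 4 (beyond the scatter) and a number 15 percentage points lower from compound 1 to compound 4 (beyond the scatter), both modest steps, whereas the 2-(((tert-butyl)carbamoyl)amino)ethyl group of compound 3 stayed within the scatter of the same two compounds. Nothing at hand explains these numbers.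

The compounds shown leave open which part of the 2-((isopropylcarbonyl)amino)ethyl group sets compound 4 apart from compound 1 and compound 2, and whether the gap would hold up on repeated measurement. A methyl or a cyclopropyl on the same carbonyl carbon, or a longer chain between the carbonyl and the sulfonyl sulfur, would show whether this read-out follows the group on the carbonyl carbon or the chain as a whole.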